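The compounds below may be only part of what the source reports. "The series", "measured", "known", "first", "only" and "open" are said of these compounds alone.

Measured so far in a functional assay on MCF7 cells (Homo sapiens) for inhibition, read by sulforhodamine B assay; on this read-out lower numbers stand for stronger inhibition and higher numbers for weaker inhibition:
compound 1, `Cc1ccc(NC2=CC(=O)c3c(nc4n3[C@H]3OC[C@@H](O)[C@H]3OC4)C2=O)cc1C`, gives 4950 nM;
compound 2, `COc1ccc(NC2=CC(=O)c3c(nc4n3[C@H]3OC[C@@H](O)[C@H]3OC4)C2=O)cc1`, gives 4470 nM.

Within the data shown here, compound 2 and compound 1 sit within the scatter of each other, the single step between them being a 1.1-fold lower number from compound 1 to compound 2 (0.04 log units; within the scatter). Compound 3, `CCOc1ccccc1NC1=CC(=O)c2c(nc3n2[C@H]2OC[C@@H](O)[C@H]2OC3)C1=O`, differs from compound 2 by 2-ethoxyphenyl in place of 4-methoxyphenyl on an amine nitrogen. Among the measured compounds shown here, the only measured step that bears on this change is the earlier swap of the aryl group on the same amine nitrogen, a 1.1-fold lower number from compound 1 to compound 2 (0.04 log units; within the scatter), which stayed within the scatter; no shift beyond the scatter is therefore expected in this assay. Compound 3 is estimated at 4500 nM (range 1500 nM to 13000 nM). This expectation amounts to a step of a 1.0-fold higher number from compound 2 to compound 3 (0.00 log units; within the scatter).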

Compound 3, half-maximal inhibitory concentration: > 4000 nM
Compound 3: no number, only a limit; the forecaster's own chance of this, stated with the estimate: 5%; the middle value lies beyond the limit too.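

Compound 3 gives only a limit, > 4000 nM, and not a number, so its steps from compound 1 and compound 2 cannot be read. As far as these compounds go, whether 2-ethoxyphenyl in place of 4-methoxyphenyl changes the inhibition at all stays open.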